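Series notes: isoquinolin-3-yl in place of 5-bromopyrimidin-2-yl

A few compounds are considered here, and "the series" means these few. Any claim that something is new, unique, unknown or untested is made for them only; others in the source may bear on it.

Measured so far:
compound 1 `CC1(C)[C@@H]2CC[C@@]1(CS(=O)(=O)N1CCN(c3ncc(C(F)(F)F)cn3)CC1)C(=O)C2` — 316 nM
compound 2 `CC1(C)[C@@H]2CC[C@@]1(CS(=O)(=O)N1CCN(c3ncc(Br)cn3)CC1)C(=O)C2` — 631 nM

In a functional assay on CHO-K1 cells for antagonist activity at C-X-C chemokine receptor type 3 (Homo sapiens), read by FLIPR and calcium flux (a lower number here means a stronger inhibitor, a higher number a weaker inhibitor), compound 1 gives 316 nM and compound 2 gives 631 nM. Compound 2 carries the highest number of the two, with compound 1 nearest; the step of a 2.0-fold higher number from compound 1 to compound 2 (0.30 log units; within the scatter) lies within the scatter.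

Compound 3 `CC1(C)[C@@H]2CC[C@@]1(CS(=O)(=O)N1CCN(c3cc4ccccc4cn3)CC1)C(=O)C2` differs from compound 2 in one place: isoquinolin-3-yl in place of 5-bromopyrimidin-2-yl on an amine nitrogen in a ring. Going by the values given here, no measured step covers this change; the single step, a 2.0-fold higher number from compound 1 to compound 2 (0.30 log units; within the scatter), concerns a different group and is within the scatter, so it gives no direction. Compound 3 is expected to land near compound 2, with the step of a 1.1-fold lower number from compound 2 to compound 3 (0.02 log units; within the scatter) carrying a wide uncertainty. The estimate for compound 3 is 600 nM, within a range from 120 nM to 3000 nM.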

Compound 3, half-maximal inhibitory concentration: 15800 nM
Compound 3: middle estimate off by 26-fold (1.42 log units), on the low side; measured number above the stated range.
By their numbers in this assay, from the lowest: compounds 1 and 2 (each within the scatter of the next); then compound 3.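

On the amine nitrogen in the ring, exchanging the pyrimidin-2-yl groups for isoquinolin-3-yl is not tolerated in this assay, giving a 25-fold higher number from compound 2 to compound 3 (1.40 log units; beyond the scatter) and a 50-fold higher number from compound 1 to compound 3 (1.70 log units; beyond the scatter). This position therefore discriminates far more sharply between whole aromatic groups than the earlier bromo for trifluoromethyl exchange showed, where the result was a 2.0-fold higher number from compound 1 to compound 2 (0.30 log units; within the scatter). No available evidence bears on what underlies this loss.

The compounds shown do not separate the added carbon-only ring from the loss of a ring nitrogen. A simple phenyl or pyridin-2-yl group here would help to distinguish the two.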